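From phenyl to 4-bromophenyl at an assay limit

The source may report more compounds than this note shows. Statements on the series, on what has been measured and on what is new or still open speak of the compounds shown alone.

Compound 1 `C/C(=N\Nc1nc(-c2ccccc2)cs1)c1sc(C)nc1C` gives > 100 ug/mL in a toxicity assay on MCF7 cells (Homo sapiens) for cytotoxicity, read by MTT assay (on this read-out higher numbers stand for weaker inhibition of growth and lower numbers for stronger inhibition of growth), and this value is a limit, not a number. Compound 2 `C/C(=N\Nc1nc(-c2ccc(F)cc2)cs1)c1sc(C)nc1C` gives > 100 ug/mL in this assay, which is again a limit. Compound 3 `C/C(=N\Nc1nc(-c2ccc(Cl)cc2)cs1)c1sc(C)nc1C` gives > 100 ug/mL in this assay, which is also a limit. Compound 1 therefore has no exact standing, and the measured set rests on (the limit of > 100 ug/mL in this assay, at which 3 of the 3 values shown sit).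

Compound 4 `C/C(=N\Nc1nc(-c2ccc(Br)cc2)cs1)c1sc(C)nc1C` differs from compound 1 by bromo in place of hydrogen on an aromatic carbon, para to a large group: bromo in place of hydrogen on an aromatic carbon. The closest measured changes are fluoro in place of hydrogen, a step that the two limits leave unreadable from compound 1 to compound 2, and chloro in place of hydrogen, a step that the two limits leave unreadable from compound 1 to compound 3. Chloro in place of fluoro also bears on it, a step that the two limits leave unreadable from compound 2 to compound 3. None of these steps has a readable size, so they give no direction, and no change beyond the scatter is expected in this assay. The estimated step is a number no higher from compound 1 to compound 4 (the limit leaves the size open). Compound 4 is expected at 100 ug/mL, with an estimated range of 50 ug/mL to 200 ug/mL.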

Compound 4, concentration for 50% growth inhibition: > 100 ug/mL
Compound 4 ended at the assay's limit; the forecaster's own chance of this, stated with the estimate: 80%; the middle value sits exactly at the limit.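

Among these compounds, no step from compound 4 to compound 1, compound 2 or compound 3 can be read in this assay, as all four compounds stand at one limit: the limit of > 100 ug/mL in this assay, at which 4 of the 4 values shown sit. The compounds shown leave open how strongly each inhibits growth, and whether hydrogen, fluoro, chloro or bromo at this place makes any difference.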